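The compounds below may be only part of what the source reports. "The series", "measured", "known", "first", "only" and "open" are said of these compounds alone.

Compound 1 `CC(C)C(=O)O[C@H]1C[C@@H](C)C=C2C=C[C@H](C)[C@H](CC[C@@H]3C[C@@H](O)CC(=O)O3)C21` is an ester whose acid part carries an isopropyl group on the carbonyl carbon. In an assay for inhibition of 3-hydroxy-3-methylglutaryl-coenzyme A reductase (Rattus norvegicus) (on this read-out lower numbers stand for stronger inhibition and higher numbers for weaker inhibition), compound 1 gives 7.7 nM, the second highest of the three numbers measured. Compound 2 `CCC(CC)(CC)C(=O)O[C@H]1C[C@@H](C)C=C2C=C[C@H](C)[C@H](CC[C@@H]3C[C@@H](O)CC(=O)O3)C21`, with a larger alkyl group on the carbonyl carbon, gives 1.4 nM, and compound 3 `C[C@H]1C=C2C=C[C@H](C)[C@H](CC[C@@H]3C[C@@H](O)CC(=O)O3)C2[C@@H](OC(=O)C2CC2)C1`, with cyclopropyl, gives 38.6 nM. The measured steps were a 5.5-fold lower number from compound 1 to compound 2 (0.74 log units; beyond the scatter), a 5.0-fold higher number from compound 1 to compound 3 (0.70 log units; beyond the scatter) and a 28-fold higher number from compound 2 to compound 3 (1.44 log units; beyond the scatter). Compound 4 `CC(CC(=O)O[C@H]1C[C@@H](C)C=C2C=C[C@H](C)[C@H](CC[C@@H]3C[C@@H](O)CC(=O)O3)C21)C(F)(F)F` alters the same place: 2-(trifluoromethyl)propyl in place of isopropyl on a carbonyl carbon. The step from compound 1 to compound 2 also enlarged the group on the carbonyl carbon and is the one that bears on this change; it lowered the number. A similar but somewhat smaller shift is expected here. For compound 4 the expected step is a 2.2-fold lower number from compound 1 to compound 4 (0.34 log units; beyond the scatter). Compound 4 is estimated at 3.5 nM, within 1.5 nM to 9 nM.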

Compound 4, half-maximal inhibitory concentration: 3.5 nM
For compound 4 middle estimate and measured number coincide at the digits printed, and the stated range covers the measured number.
By their numbers in this assay, from the lowest: compound 2; then compound 4; then compound 1; then compound 3.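

A second, different enlarged group on the carbonyl carbon also lowers the number, with a 2.2-fold lower number from compound 1 to compound 4 (0.34 log units; beyond the scatter), so this gain is not confined to the 1,1-diethylpropyl group of compound 2. The fluorine-bearing group does not reach that group's result, with a 2.5-fold higher number from compound 2 to compound 4 (0.40 log units; beyond the scatter), but it remains well ahead of cyclopropyl, with an 11-fold lower number from compound 3 to compound 4 (1.04 log units; beyond the scatter). No measurement here explains these shifts. The compounds shown leave open how an amine, a carboxylic acid or a longer unfluorinated alkyl chain on this carbonyl carbon would compare.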